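The source may hold more compounds than are shown below. What is called first, only, known or untested is meant among the compounds shown, and "the series" means these compounds.

The measured compounds are compound 1 `CC[C@H](C)[C@H](N)CN(C(=O)[C@@H]1C[C@H]1c1ccc(OC)cc1)c1ccc(-c2ccccc2)cc1` and compound 2 `CC[C@H](C)[C@H](N)CN(C(=O)[C@@H]1C[C@H]1c1ccccn1)c1ccc(-c2ccccc2)cc1`.

In a functional assay for agonist activity at G protein-coupled receptor 88 (Homo sapiens), read by HTRF and cAMP accumulation (on this read-out higher numbers stand for an effect only at larger amounts of compound and lower numbers for an effect already at smaller amounts), compound 1 gives only a limit, > 25000 nM. In this assay, within the data shown here, compound 2 gives 130 nM, the only number recorded, so it stands alone on the scale with no measured neighbour to rank against. The step of an at least 190-fold lower number from compound 1 to compound 2 (2.28 log units; beyond the scatter) was large, though its size rests on the limit (the limit of > 25000 nM in this assay, at which 1 of the 2 values shown sits).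

Compound 3 `CC[C@H](C)[C@H](N)CN(C(=O)[C@@H]1C[C@H]1c1ncccn1)c1ccc(-c2ccccc2)cc1` differs from compound 2 by pyrimidin-2-yl in place of pyridin-2-yl on a saturated ring carbon. Among the measured compounds shown here, only the step from compound 1 to compound 2 bears on this change, and it shows that the aromatic group on the saturated ring carbon matters greatly in this assay. It does not show what a second ring nitrogen in that group does. The account therefore expects a modest step in this assay, most likely toward a somewhat higher number: a 2.3-fold higher number from compound 2 to compound 3 (0.36 log units; beyond the scatter). For compound 3 the expected value is 300 nM, in the range 60 nM to 2000 nM.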

Compound 3, half-maximal effective concentration: 130 nM
Estimate against measurement, compound 3: 2.3-fold (0.36 log units) above; measured number inside the range.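

In this assay, among these compounds, the change of pyridin-2-yl to pyrimidin-2-yl gives no change at the digits printed from compound 2 to compound 3 (within the scatter), so on this saturated ring carbon the added ring nitrogen leaves the read-out where it was, something the earlier compounds could not show. Pyrimidin-2-yl in place of 4-methoxyphenyl gives an at least 190-fold lower number from compound 1 to compound 3 (2.28 log units; beyond the scatter), so the large gap now holds for two nitrogen-containing six-membered aromatic rings and not for pyridin-2-yl alone. Compound 1 gives only a limit, and the size of both of its steps rests on it: the limit of > 25000 nM in this assay, at which 1 of the 3 values shown sits.

The compounds shown leave open whether a plain phenyl group on this carbon would read like compound 2 and compound 3 or like compound 1, and so whether a ring nitrogen or the loss of the methoxy group goes with the gap. They also leave open how pyrazin-2-yl or pyrimidin-4-yl would read in this assay.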